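The compounds below may be only part of what the source reports. "The series", "measured", "known", "first", "only" and "open" are said of these compounds alone.

Measured compounds:
compound 1, `CCCN(CCC)c1cc(C)nc2c(-c3ccc(Cl)cn3)c(C)nn12`, 88 nM
compound 2, `CCCN(CCC)c1cc(C)nc2c(-c3ncc(N(CC)CC)cc3C)c(C)nn12`, 13 nM
compound 3, `CCCN(CCC)c1cc(C)nc2c(-c3ncc(N=O)cc3C)c(C)nn12`, 100 nM

In an assay on isolated protein for binding affinity to corticotropin-releasing factor receptor 1 (Homo sapiens) (on this read-out higher numbers stand for weaker inhibition and lower numbers for stronger inhibition), compound 3 gives the highest of the three numbers. Compound 1 lies nearest, and the step of a 1.1-fold higher number from compound 1 to compound 3 (0.06 log units; within the scatter) stays within the scatter, so the two are not told apart. Compound 2 lies furthest, and the step of a 7.7-fold higher number from compound 2 to compound 3 (0.89 log units; beyond the scatter) is a modest one beyond the scatter, with the diethylamino-bearing compound 2 at the lower number.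

Compound 4, `CCCN(CCC)c1cc(C)nc2c(-c3ncc(I)cc3C)c(C)nn12`, is the next compound to be measured. It differs from compound 3 by one iodine atom in place of a group of 2 heavy atoms (1 nitrogen, 1 oxygen; no ring), on an aromatic carbon, that is, an iodo group takes the place of the nitroso group on the pyridine ring, two atoms from the ring nitrogen, meta to the methyl group and para to the large group.

Within the data shown here, no measured step swaps a halogen for a nitroso group at this position. The step of a 7.7-fold higher number from compound 2 to compound 3 (0.89 log units; beyond the scatter) shows that the group at this place can move the number by a modest amount, and the step of a 1.1-fold higher number from compound 1 to compound 3 (0.06 log units; within the scatter) shows that a chloro-bearing ring, though of a different pattern, lands close to compound 3. Compound 4 is therefore expected to come out near compound 3 or somewhat lower, an expected step of a 2.0-fold lower number from compound 3 to compound 4 (0.30 log units; within the scatter) in this assay. The estimate for compound 4 in this assay is 50 nM, with a range from 15 nM to 160 nM.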

Compound 4, inhibition constant: 6.6 nM
The estimate for compound 4 lay 7.6-fold (0.88 log units) above the measured number; measured number below the stated range.
By their numbers in this assay, from the lowest: compounds 4 and 2 (each within the scatter of the next); then compounds 1 and 3 (each within the scatter of the next).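

In this assay, iodo in place of the nitroso group on this aromatic carbon gives a 15-fold lower number from compound 3 to compound 4 (1.18 log units; beyond the scatter) and is a large step, larger than the earlier steps at this place had shown, so the choice of group here can matter a great deal even when the group entering is a single atom. The diethylamino group and the iodo group, so unlike in size, are not told apart: a 2.0-fold lower number from compound 2 to compound 4 (0.29 log units; within the scatter) stays within the scatter, which leaves the nitroso compound apart from both of them and shows that the number does not simply follow the heavy atoms of the group at this place. The change to 5-iodo-3-methylpyridin-2-yl from 5-chloropyridin-2-yl gives a 13-fold lower number from compound 1 to compound 4 (1.12 log units; beyond the scatter) and is also large, but it alters the halogen and the methyl group together, and nothing measured here accounts for any of these shifts.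

The compounds shown leave open how far the halogen and the methyl group each contribute to that last step, as a chloro or bromo group on the ring that keeps the methyl group would show. They also leave open how a primary amine, a methoxy group or a carboxylic acid at this place would read in this assay against the iodo and diethylamino groups.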